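This account rests on a few compounds, and the source may have more. Where it says the series, first, only, none or still open, it means among the compounds named here.

Measured compounds:
compound 1 `CCNCCn1c(N2CCN(C)CC2)nc2ccccc21` — 290 nM
compound 2 `CCCCN1CCCN(c2nc3ccccc3n2CCOCC)CC1` — 8.4 nM
compound 3 `CCCN1CCN(c2nc3ccccc3n2CCOCC)CC1` — 16 nM

All three numbers come from a functional assay on ileum for inhibition of histamine H1 receptor (Cavia porcellus); on this read-out higher numbers stand for weaker inhibition and lower numbers for stronger inhibition. Compound 1 stands highest of the three. Its nearest neighbour is compound 3, whose number lies well below it, beyond the scatter; compound 2 lies further below still, also beyond the scatter. For the measured compounds named here, both of those compounds differ from compound 1 in more than one place, so no step between measured compounds that isolates a single change is available, and their gap to compound 1 cannot be assigned to one feature.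

Compound 4 `CCCCOCCn1c(N2CCN(C)CC2)nc2ccccc21` has not been measured. It differs from compound 1 in one place: butoxy in place of ethylamino on a saturated chain carbon, two bonds along the chain from an aromatic nitrogen. The shared core and the remainder of compound 1 are unchanged. Going by the values given here, no measured pair tests this change on its own. What the numbers do show is that compounds 2 and 3, neither of which carries the ethylamino group, both sit well below compound 1. On that basis the step of a 6.4-fold lower number from compound 1 to compound 4 (0.81 log units; beyond the scatter) is expected to go downward, beyond the scatter. The uncertainty is wide; the other differences in compounds 2 and 3 are not separated from the chain. Compound 4 is estimated at 45 nM, with a range of 10 nM to 180 nM.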

Compound 4, half-maximal inhibitory concentration: 38 nM
Estimate against measurement, compound 4: 1.2-fold (0.07 log units) above, within the range that was stated.
By their numbers in this assay, from the lowest: compounds 2 and 3 (each within the scatter of the next); then compound 4; then compound 1.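

The series now has its first single-place reading in this assay: the change at this position gives a 7.6-fold lower number from compound 1 to compound 4 (0.88 log units; beyond the scatter) and shows that the number here responds to the chain group alone, with the rest of compound 1 unchanged. Ethylamino carries a hydrogen-bond donor and butoxy carries none, but butoxy is also the larger group, so this one step cannot be divided between the change of heteroatom and the change in chain length. Nothing available bears on the origin of this step.

A butylamino group at the same place would keep the nitrogen while matching the butoxy chain, and an ethoxy group would keep the oxygen while matching the ethylamino chain, so these two groups would separate the heteroatom from the chain length. Steps from compound 4 to compounds 2 and 3 cannot be read, since those compounds differ from it in more than one place, and the contribution of the other parts of the structure remains unassigned.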